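Hemolysis notes: fluoro in place of chloro

A few compounds are considered here, and "the series" means these few. Any claim that something is new, unique, unknown or untested is made for them only; others in the source may bear on it.

Measured so far:
- compound 1 `CC(=NNC(=S)Nc1ccccc1F)c1ccccn1`: in an ADME assay on cells (Erythrocyte, Homo sapiens), read by hemolysis, with a stated time of 1 h (on this read-out higher numbers stand for weaker inhibition and lower numbers for stronger inhibition), compound 1 gives > 10000 nM, which is a limit of the assay and not a number.
- compound 2 `CC(=NNC(=S)Nc1ccc(Cl)cc1)c1ccccn1`: in this assay compound 2 gives > 10000 nM, again a limit and not a number.

Both values shown sit at the same place, (the limit of > 10000 nM in this assay, at which 2 of the 2 values shown sit). Compound 2 therefore stands at that limit with no number of its own, and nothing within the pair can be ordered or compared for size.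

Compound 3 `CC(=NNC(=S)Nc1ccc(F)cc1)c1ccccn1` is not yet measured. It differs from compound 2 in one place: fluoro in place of chloro on an aromatic carbon. Among the compounds with values here, no step between measured compounds is available, so the effect of this exchange cannot be read from the series itself. In this assay the expected step is a step that the limit leaves unreadable from compound 2 to compound 3, that is, no change beyond the usual scatter in either direction. For compound 3 the estimate in this assay is 15000 nM, with a range from 8000 nM to 40000 nM, and the assay is expected most likely to report only a limit once more.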

Compound 3, half-maximal inhibitory concentration: > 10000 nM
Compound 3: no number, only a limit; the forecaster's own chance of this, stated with the estimate: 85%; the middle value does not contradict the limit.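

The exchange of chloro for fluoro gives no readable step between compound 2 and compound 3 in this assay. Each has only a limit and not a number, as does compound 1: the limit of > 10000 nM in this assay, at which 3 of the 3 values shown sit.

The compounds shown leave open whether this exchange affects hemolysis at all, and where the half-maximal concentration of any of the three lies.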